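The compounds below may be only part of what the source reports. "The series", "measured", "known", "first", "only" and "open" are said of these compounds alone.

For the measured compounds named here, in a functional assay on the whole organism for inhibition, with Rattus norvegicus as the target, read by paw edema (a higher number here means that more compound is needed for the effect, a lower number that less compound is needed), compound 1 `O=C(O)c1cc(-n2cccc2)ccc1O` gives 50 mg/kg, the lower of the two numbers measured so far, while compound 2 `O=C(O)c1cc(C2N=NN=N2)ccc1O` gives 110 mg/kg. Compound 3 `O=C(O)c1cc(-c2cccs2)ccc1O` keeps the core of compound 1 and alters one group: thiophen-2-yl in place of 1H-pyrrol-1-yl on an aromatic carbon. Going by the values given here, the only measured step at this place is a 2.2-fold higher number from compound 1 to compound 2 (0.34 log units; beyond the scatter), a modest one that brought in a non-aromatic ring. Thiophen-2-yl is aromatic, like the 1H-pyrrol-1-yl it replaces, so no change beyond the scatter is expected, and no direction is favoured. The estimated step is a 1.2-fold higher number from compound 1 to compound 3 (0.08 log units; within the scatter). Compound 3 is expected at 60 mg/kg, with an estimated range of 25 mg/kg to 130 mg/kg.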

Compound 3, dose for half-maximal effect: 60 mg/kg
Beside the measured number, compound 3's estimate shows no gap at the digits printed; low and high end bracket the measured number.
By their numbers in this assay, from the lowest: compounds 1, 3 and 2 (each within the scatter of the next, the first and the last beyond it).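

Swapping 1H-pyrrol-1-yl for thiophen-2-yl on this aromatic carbon leaves this assay practically unchanged, with a 1.2-fold higher number from compound 1 to compound 3 (0.08 log units; within the scatter), so this position accepts a second five-membered aromatic ring with no change beyond the scatter. The other new step is a 1.8-fold lower number from compound 2 to compound 3 (0.26 log units; within the scatter), so these two compounds cannot be told apart either. No supporting data here explain these results.

As far as these compounds go, it remains open how a phenyl ring, an amine or a longer chain at this position would compare.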